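The compounds below may be only part of what the source reports. "The series", "measured", "known", "first", "only" and "open" are said of these compounds alone.

Compound 1 `COc1ccc(S(=O)(=O)Oc2ccccc2NC(=O)Nc2ccccc2)cc1` is the shared core joined through a urea. In a functional assay on HCT-15 cells (Homo sapiens) for antiproliferative activity (on this read-out higher numbers stand for weaker inhibition and lower numbers for stronger inhibition), compound 1 reaches only the assay's limit, > 10000 nM. Compound 2 `COc1ccc(S(=O)(=O)Oc2ccccc2NC(=O)c2ccnc3ccccc23)cc1` likewise stops at a limit, > 10000 nM. Compound 3 `COc1ccc(S(=O)(=O)Oc2ccccc2NC(=O)c2ccccc2)cc1`, the benzamide, gives 310 nM. Two values therefore sit at the limit of > 10000 nM in this assay, at which 2 of the 3 values shown sit, so the step that the two limits leave unreadable from compound 1 to compound 2 cannot be read, whereas an at least 32-fold lower number from compound 1 to compound 3 (1.50 log units; beyond the scatter) and an at least 32-fold lower number from compound 2 to compound 3 (1.50 log units; beyond the scatter) are large. Compound 4 `COc1ccc(S(=O)(=O)Oc2ccccc2NC(=O)c2cccnc2)cc1` is not yet measured; it differs from compound 1 by pyridin-3-yl in place of anilino on a carbonyl carbon, which, cut one bond further out, reads phenylcarbamoyl to (pyridin-3-yl)carbonyl. As compound 4 is an amide like compound 3, a large gain is expected, an at least 10-fold lower number from compound 1 to compound 4 (1.00 log units; beyond the scatter), though smaller than an at least 32-fold lower number from compound 1 to compound 3 (1.50 log units; beyond the scatter). Compound 4 is estimated at 1000 nM, between 200 nM and 10000 nM.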

Compound 4, half-maximal inhibitory concentration: > 3000 nM
Compound 4: no number, only a limit; the forecaster's own chance of this, stated with the estimate: 25%; middle value at least 3.0-fold (0.47 log units) away from the limit.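

In this assay compound 4 gives > 3000 nM, which is a limit and not a number. Pyridin-3-yl in place of phenyl on a carbonyl carbon gives an at least 9.6-fold higher number from compound 3 to compound 4 (0.98 log units; beyond the scatter), so the amide link alone does not keep the activity, and a change within a single six-membered aromatic ring is enough to lose much of it. The steps to compound 4 from compound 1 and from compound 2 cannot be read.

The compounds shown leave open how far past its limit compound 4 lies. They also leave open whether pyridin-4-yl or a phenyl carrying an amino group on the carbonyl carbon would keep the value of compound 3.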